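A few compounds are considered here, and "the series" means these few. Any claim that something is new, unique, unknown or untested is made for them only; others in the source may bear on it.

Compound 1 `CS/C(=N\C(=O)c1ccno1)NC(=O)c1ccno1`. In an ADME assay on MCF-10A cells (Homo sapiens) for cytotoxicity, read by MTT assay, with a stated time of 72 h (a higher number here means a weaker inhibitor of growth, a lower number a stronger inhibitor of growth), compound 1 reaches only the limit > 100000 nM.
Compound 2 `O=C(/N=C(/NC(=O)c1cc(-c2ccccc2)nc2ccccc12)[Se]Cc1ccccc1)c1cc(-c2ccccc2)nc2ccccc12`. In this assay compound 2 gives 45600 nM.
Compound 3 `C[Se]/C(=N\C(=O)c1ccno1)NC(=O)c1ccno1`. In this assay compound 3 gives 15400 nM.

Among the two numbers known, compound 2 stands highest, with compound 3 the nearest and lower. Among the compounds with values here, the one measured step, an at least 6.4-fold lower number from compound 1 to compound 3 (0.81 log units; beyond the scatter), concerns the atom bound to the amidine carbon and does not touch the group on selenium. Compound 4 `C[Se]/C(=N\C(=O)c1cc(-c2ccccc2)nc2ccccc12)NC(=O)c1cc(-c2ccccc2)nc2ccccc12` differs from compound 2 by hydrogen in place of phenyl on a saturated chain carbon bound to a selenium atom. Within the data shown here, no measured step bears on that change; compound 3 carries the methyl group on selenium but a different acyl part, so its value shows only that such a compound can sit lower than compound 2. The step from compound 2 to compound 4 is therefore expected to be small, a 1.5-fold lower number from compound 2 to compound 4 (0.18 log units; within the scatter), and compound 4 is estimated at 30000 nM, between 10000 nM and 90000 nM.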

Compound 4, concentration for total growth inhibition: 20100 nM
Beside the measured number, compound 4's estimate is 1.5-fold (0.17 log units) above it, within the range that was stated.
By their numbers in this assay, from the lowest: compounds 3 and 4 (each within the scatter of the next); then compound 2. At a limit, above all of these: compound 1.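

The group on selenium now has a measured step of its own: with the acyl parts shared, a 2.3-fold lower number from compound 2 to compound 4 (0.36 log units; beyond the scatter) in this assay as benzyl gives way to methyl. The earlier step changed only the atom on a carbon with a double bond to nitrogen, so this is a second place where the number moves. Nothing in the data shown gives a reason for this step.

On these data alone, what a longer chain such as propyl or an amine on that carbon would give remains open. So does whether benzyl in place of methyl would shift compound 3 similarly.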